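Taking the Chlorine off Compound 1

The compounds below may be only part of what the source reports. "The series", "measured", "known", "first", "only" and "open" are said of these compounds alone.

For the measured compounds named here, in a functional assay on MCF7 cells (Homo sapiens) for antiproliferative activity, read by MTT assay, with a stated time of 48 h (a higher number here means a weaker inhibitor, a lower number a stronger inhibitor), compound 1 `COC(=O)/C(=C/c1ccccc1)CN1C(=O)[C@@H](OC)[C@H]1c1ccc(Cl)cc1` gives 15300 nM as the higher of the two numbers so far. In this assay compound 3 `CCOC(=O)/C(=C/c1ccccc1)CN1C(=O)[C@@H](OC)[C@H]1c1ccccc1Br` gives 5790 nM and so sits lower by more than the usual scatter, but it differs from compound 1 in more than one place. For compound 2 `COc1ccc(OC)c([C@@H]2[C@H](OC)C(=O)N2C/C(C#N)=C/c2ccccc2)c1` the entry reads no result reported, so it adds nothing to the comparison.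

Compound 4 `COC(=O)/C(=C/c1ccccc1)CN1C(=O)[C@@H](OC)[C@H]1c1ccccc1` has not been measured yet. It differs from compound 1 by a single change hydrogen in place of chloro on an aromatic carbon with hydrogen in place of chloro on an aromatic carbon, turning 4-chlorophenyl into phenyl.

Going by the values given here, no two measured compounds differ in only one place, so nothing here shows directly what this change does. With so little to go on, no step beyond the scatter is expected in this assay and the estimated step is a 1.1-fold lower number from compound 1 to compound 4 (0.04 log units; within the scatter) as the working figure. Compound 4 is expected near 14000 nM with an estimated range from 5000 nM to 40000 nM in this wide window.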

Compound 4, half-maximal inhibitory concentration: 12900 nM
Compound 4: middle estimate off by 1.1-fold (0.04 log units), on the high side, and the stated range covers the measured number.
By their numbers in this assay, from the lowest: compound 3; then compounds 4 and 1 (each within the scatter of the next).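

In this assay, for the compounds shown here, the first comparison in this set that differs in only one place comes out as a small step (a 1.2-fold lower number from compound 1 to compound 4 (0.07 log units; within the scatter)). At this position, the chloro group and hydrogen therefore cannot be told apart, so the chlorine is not needed to keep the antiproliferative reading at this level. No separate measurement is available to explain this result.

The compounds shown leave open whether a different group at the same place on the ring, such as an amine or a carboxylic acid, would shift the number beyond the scatter. They also leave open whether hydrogen in place of chloro would read the same way if another part of the molecule, such as the methyl ester, were changed.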